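The source may hold more compounds than are shown below. What is called first, only, known or untested is meant among the compounds shown, and "the series" means these compounds.

Compound 1 `CCC(=O)Nc1cc(C(=O)Nc2ccc(OC)cc2)ccc1OC` is the anchor of this series. In a toxicity assay on Huh-7.5 cells (Homo sapiens) for inhibition, read by MTT assay, with a stated time of 96 h (on this read-out higher numbers stand for lower toxicity in this test and lower numbers for higher toxicity in this test), compound 1 gives 109000 nM. Going by the values given here, only two of the three values shown are numbers, and compound 1 and compound 3 lie within the scatter of each other. Compound 3 `CCC(=O)Nc1cc(C(=O)Nc2ccc(OC)cc2)ccc1OCCCN1CCN(C)CC1` gives 127000 nM in this assay, a change described by a 1.2-fold higher number from compound 1 to compound 3 (0.07 log units; within the scatter). Compound 2 `CCC(=O)Nc1cc(C(=O)Nn2c(C)nnc2S)ccc1OC` reaches only a limit of this assay, > 200000 nM. The step of an at least 1.8-fold higher number from compound 1 to compound 2 (0.26 log units; that floor lies within the scatter) therefore has a floor rather than a size, and the limit of > 200000 nM in this assay, at which 1 of the 3 values shown sits, marks where that floor sits.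

Compound 4 `CCC(=O)Nc1cc(C(=O)Nc2ccc(-c3cc4ccccc4[nH]3)cc2)ccc1OC` changes the ring on the amide-type nitrogen differently: 1H-indol-2-yl in place of methoxy on an aromatic carbon. Neither measured step swaps a methoxy for a bicyclic aromatic group on that ring, so both bear on it only loosely. Both stayed within the scatter, so no step beyond the scatter is expected here either, in either direction. Compound 4 is estimated to give 90000 nM in this assay, between 35000 nM and 200000 nM, which means an expected step of a 1.2-fold lower number from compound 1 to compound 4 (0.08 log units; within the scatter).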

Compound 4, half-maximal cytotoxic concentration: 65600 nM
Estimate against measurement, compound 4: 1.4-fold (0.14 log units) above; the measured number falls inside the stated range.
By their numbers in this assay, from the lowest: compounds 4, 1 and 3 (each within the scatter of the next). At a limit, above all of these: compound 2.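

Replacing methoxy with 1H-indol-2-yl brings in 9 heavy atoms and two aromatic rings, yet this assay shows only a 1.7-fold lower number from compound 1 to compound 4 (0.22 log units; within the scatter). This aromatic carbon, para to a large group, therefore takes a much bigger group than methoxy without a step beyond the scatter, something compound 2 and compound 3 could not show, as neither changes this carbon. Nothing measured here bears on why this step stays so small.

Going by these compounds, it remains open whether an amine, a carboxylic acid or a longer chain on this same carbon would also stay within the scatter of compound 1. Also open, on these data alone, is whether naphthyl, whose rings hold only carbon, would read the same as 1H-indol-2-yl, which would help show whether the ring nitrogen plays any part.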